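Aryl amine swap on the shared core: compound 4

The source may hold more compounds than are shown below. What is called first, only, known or untested is meant among the compounds shown, and "the series" means these compounds.

Compound 2 `Cc1cc(Cl)ccc1Nc1ncc(C(F)(F)F)c(N2Cc3cccc(N(C)S(C)(=O)=O)c3C2)n1` stands at the ceiling of a functional assay on OVCAR-3 cells (Homo sapiens) for antiproliferative activity, read by spectrophotometry, with a stated time of 2 days; a higher number here means a weaker inhibitor of growth, a lower number a stronger inhibitor of growth: compound 2 gives > 30000 nM, which is a limit of the assay and not a number. Compound 1 `COc1ccc(Nc2ncc(C(F)(F)F)c(N3Cc4cccc(N(C)S(C)(=O)=O)c4C3)n2)cc1C(F)(F)F` stands at the same place, since in this assay compound 1 gives > 30000 nM, again a limit. Only compound 3 `COc1cc(Nc2ncc(C(F)(F)F)c(N3Cc4cccc(N(C)S(C)(=O)=O)c4C3)n2)cc(OC)c1` returns a number; in this assay compound 3 gives 630 nM. The step between the two limits is a step that the two limits leave unreadable from compound 1 to compound 2. Toward compound 3 the steps are an at least 47-fold lower number from compound 2 to compound 3 (1.67 log units; beyond the scatter) and an at least 47-fold lower number from compound 1 to compound 3 (1.67 log units; beyond the scatter), both starting from the limit of > 30000 nM in this assay, at which 2 of the 3 values shown sit.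

Compound 4 `CN(c1cccc2c1CN(c1nc(Nc3cccc(C(F)(F)F)c3)ncc1C(F)(F)F)C2)S(C)(=O)=O` is compound 2 with one change: 3-(trifluoromethyl)phenyl in place of 4-chloro-2-methylphenyl on a nitrogen on an aromatic ring. For the measured compounds named here, no measured step covers this exact swap. The group entering compound 4 carries the trifluoromethyl also present on the aryl of compound 1, and compound 1 gives > 30000 nM, a limit. Both measured aryl amines without the 3,5-dimethoxyphenyl sit at the limit, so compound 4 is expected to stay weak. The estimate for compound 4 in this assay is 20000 nM, with a range from 6000 nM to 60000 nM. That estimate means an expected step of an at least 1.5-fold lower number from compound 2 to compound 4 (0.17 log units; that floor lies within the scatter), with a real chance that only a limit is reported.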

Compound 4, concentration for 50% growth inhibition: > 30000 nM
Compound 4: no number, only a limit; the forecaster's own chance of this, stated with the estimate: 55%; middle value at least 1.5-fold (0.17 log units) away from the limit.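

In this assay compound 4 gives > 30000 nM, which is a limit of the assay and not a number. On this nitrogen, 3-(trifluoromethyl)phenyl in place of 3,5-dimethoxyphenyl gives an at least 47-fold higher number from compound 3 to compound 4 (1.67 log units; beyond the scatter), while the steps to compound 4 from the other two aryl amines cannot be read, both ends being limits. A third aryl group, this one with a trifluoromethyl as its only substituent, thus joins compound 1 and compound 2, and compound 3 remains the only one of the aryl amines shown to return a number: the limit of > 30000 nM in this assay, at which 3 of the 4 values shown sit.

From the compounds shown here alone, whether compound 3 needs both methoxy groups stays open, and a 3-methoxyphenyl on this nitrogen would separate them. Also open, going by these compounds, is whether a morpholine on the aryl ring, or a 3,5-diethoxyphenyl, would return a number.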